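Methylating the Amine: a Change Expected to Stay Flat

This account rests on a few compounds, and the source may have more. Where it says the series, first, only, none or still open, it means among the compounds named here.

Of the compounds shown here, three have been measured in a functional assay on HEK293 cells for inhibition of 5-hydroxytryptamine receptor 6 (Homo sapiens), read by cAMP accumulation; on this read-out higher numbers stand for weaker inhibition and lower numbers for stronger inhibition. Compound 1 `CNc1nn2c(CN)cc(C)nc2c1S(=O)(=O)c1ccccc1` gives 1.86 nM. Compound 2 `CNc1nn2c(CN(C)C)cc(C)nc2c1S(=O)(=O)c1ccccc1` gives 1.82 nM. Compound 3 `CNc1nn2c(C)c(CN)c(C)nc2c1S(=O)(=O)c1cccc(Cl)c1` gives 0.55 nM; it stands lowest of the three numbers, beyond the scatter from both compound 1 and compound 2.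

Compound 4 `CNc1nn2c(C)c(CN(C)C)c(C)nc2c1S(=O)(=O)c1cccc(Cl)c1` has not yet been measured in this assay. It differs from compound 3 by dimethylamino in place of amino on a saturated chain carbon bound to an aromatic carbon. Within the data shown here, the one measured step that bears on this exchange is a 1.0-fold lower number from compound 1 to compound 2 (0.01 log units; within the scatter), the same change at the same place on the shared core, and that step stayed within the scatter. Nothing else among the measured compounds speaks to this exchange. On that basis compound 4 is expected to stay close to compound 3. The expected step is no change at the digits printed from compound 3 to compound 4 (within the scatter), which is expected to lie within the scatter rather than in either direction beyond it. Compound 4 is therefore estimated at 0.55 nM, with a range from 0.25 nM to 1.2 nM.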

Compound 4, inhibition constant: 0.417 nM
Compound 4: middle estimate off by 1.3-fold (0.12 log units), on the high side, within the range that was stated.
By their numbers in this assay, from the lowest: compounds 4 and 3 (each within the scatter of the next); then compounds 2 and 1 (each within the scatter of the next).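

With a 1.3-fold lower number from compound 3 to compound 4 (0.12 log units; within the scatter), the exchange of amino for dimethylamino on a saturated chain carbon bound to an aromatic carbon now has a second reading in this assay, so the earlier result no longer rests on a single pair. On both pairs, a group counted with one hydrogen-bond donor gives way to one counted with none, and the step stays within the scatter. The two readings also agree with each other: the same change on two cores in this assay, a 1.0-fold lower number (0.01 log units; within the scatter) from compound 1 to compound 2 and a 1.3-fold lower number (0.12 log units; within the scatter) from compound 3 to compound 4, 1.3-fold (0.11 log units) apart, within the scatter of two such steps

These two pairs say nothing about how far this tolerance extends, since only amino and dimethylamino appear on this carbon. Methylamino, a ring amine such as piperidine, or an acetamide in the same place could each behave differently, and the compounds shown do not settle this.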